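The source may hold more compounds than are shown below. What is called first, only, known or untested is meant among the compounds shown, and "the series" means these compounds.

Among the compounds with values here, in an ADME assay on CHO-K1 cells (Cricetulus griseus) for cytotoxicity, read by MTT assay, with a stated time of 24 h (a lower number here means a stronger inhibitor, a higher number a weaker inhibitor), compound 1 (`CCCCCCCCCCCC(=O)Nc1nnc(S[C@@H]2O[C@H](COC(C)=O)[C@H](OC(C)=O)[C@H](OC(C)=O)[C@H]2OC(C)=O)s1`) gives 27700 nM as the only number so far. Compound 2 (`CCCCCCCCCCCCCCCCCC(=O)Nc1nnc(S[C@@H]2O[C@H](CO)[C@H](O)[C@H](O)[C@H]2O)s1`) is reported as "not active" (no number reported) with no number attached. Compound 3 (`CCCCCCCC/C=C\CCCCCCCC(=O)Nc1nnc(S[C@@H]2O[C@H](COC(C)=O)[C@H](OC(C)=O)[C@H](OC(C)=O)[C@H]2OC(C)=O)s1`) is still to be measured. Relative to compound 1 the change is dec-1-en-1-yl in place of butyl on a saturated chain carbon, seven bonds along the chain from a carbonyl carbon on a saturated chain carbon, seven bonds along the chain from a carbonyl carbon. Within the data shown here, no measured step gauges this change, so only a small move towards weaker inhibition is expected in this assay, with a 1.3-fold higher number from compound 1 to compound 3 (0.10 log units; within the scatter) as the estimated step. For compound 3 the estimated value is 35000 nM with an expected range of 14000 nM to 90000 nM for this reading.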

Compound 3, half-maximal inhibitory concentration: 26300 nM
For compound 3 the middle estimate is 1.3-fold (0.12 log units) above the measured one; the range from low to high includes it.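

In this assay, within the data shown here, the first measured step at this position, dec-1-en-1-yl in place of butyl on a saturated chain carbon, seven bonds along the chain from a carbonyl carbon, is a 1.1-fold lower number from compound 1 to compound 3 (0.02 log units; within the scatter) and so gives no separation between the two chains. Nothing measured explains this result.

On these data alone, the added carbons and the double bond enter together, so their separate contributions remain open. As far as these compounds go, a saturated decyl group at this position would separate them, and a terminal amine or carboxylic acid on the chain remains untested here.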